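The source may report more compounds than this note shows. Statements on the series, on what has been measured and on what is new or still open speak of the compounds shown alone.

Compound 1, `COc1cc(Oc2cccc(Nc3ccccc3)c2)cc(OC)c1CNCCNC(C)=O`: in a functional assay on HT-29 cells (Homo sapiens) for inhibition, read by MTT assay, with a stated time of 72 h (on this read-out higher numbers stand for weaker inhibition and lower numbers for stronger inhibition), compound 1 gives 3960 nM.
Compound 2, `COc1cc(Oc2cccc(Nc3ccccc3)c2)cc(OC)c1CN(C)C`: in this assay compound 2 gives > 20000 nM, which is a limit of the assay.

Compound 2 therefore stands only at the limit of > 20000 nM in this assay, at which 1 of the 2 values shown sits, with no number of its own. Compound 3, `COc1cc(Oc2cccc(Nc3ccccc3)c2)cc(OC)c1CNCc1ccc(Br)cc1`, differs from it in (4-bromobenzyl)amino in place of dimethylamino on a saturated chain carbon bound to an aromatic carbon. Among the measured compounds shown here, the one measured step that bears on this, an at least 5.0-fold higher number from compound 1 to compound 2 (0.70 log units; beyond the scatter), went from a secondary amine to dimethylamino and lost potency; the present change goes back to a secondary amine. A step in the gaining direction, an at least 8.0-fold lower number from compound 2 to compound 3 (0.90 log units; beyond the scatter), is expected in this assay. Compound 3 is estimated at 2500 nM, between 500 nM and 15000 nM.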

Compound 3, half-maximal inhibitory concentration: 3060 nM
Compound 3: the middle estimate sits 1.2-fold (0.09 log units) below what was measured; low and high end bracket the measured number.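

On a saturated chain carbon bound to an aromatic carbon, (4-bromobenzyl)amino in place of dimethylamino gives an at least 6.5-fold lower number from compound 2 to compound 3 (0.81 log units; beyond the scatter) in this assay, so a large benzyl-type group is compatible with activity here. This step has only a lower bound because compound 2 has a limit and no number of its own: the limit of > 20000 nM in this assay, at which 1 of the 3 values shown sits. The secondary amines read alike, with a 1.3-fold lower number from compound 1 to compound 3 (0.11 log units; within the scatter) for 4-bromophenyl in place of acetamidomethyl, so these two substituents are not told apart.

Still open, going by these compounds, is whether a primary amine or a longer chain ending in a carboxylic acid would read like compound 1 and compound 3.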